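Swapping a methoxyphenyl for a naphthyl on the pyrazole core

The compounds below may be only part of what the source reports. "The series", "measured", "known", "first", "only" and "open" are said of these compounds alone.

Measured compounds:
- compound 1, `COc1ccc(C2=NN(C3=NC(=O)/C(=C4\C(=O)Nc5ccccc54)S3)C(c3ccc(Cl)cc3)C2)cc1`, 100000 nM
- compound 2, `COc1ccc(-c2cc(-c3ccc(Cl)cc3)n(C3C(=O)Nc4ccc(Br)cc43)n2)cc1`, 13200 nM
- compound 3, `COc1ccc(-c2cc(-c3ccc(Cl)cc3)n(C3C(=O)Nc4ccc(Cl)cc43)n2)cc1`, 9400 nM

All three were tested in a functional assay on cells (Melanoma cell, Homo sapiens) for cytotoxicity, read by sulforhodamine B assay, with a stated time of 48 h; a higher number here means a weaker inhibitor of growth, a lower number a stronger inhibitor of growth. Compound 1 gives 100000 nM, the highest of the three numbers, so it is the weakest of the measured set. Compound 2 sits second highest; its nearest neighbour is compound 3, and the step of a 1.4-fold lower number from compound 2 to compound 3 (0.15 log units; within the scatter) lies within the scatter, so these two cannot be told apart. Within the data shown here, the only structural change among the measured steps is that halogen swap on the fused ring.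

Compound 4, `O=C1Nc2ccc(Br)cc2C1n1nc(-c2ccc3ccccc3c2)cc1-c1ccc(Cl)cc1`, is not yet measured. It differs from compound 2 in one place: naphthalen-2-yl in place of 4-methoxyphenyl on an aromatic carbon. Among the measured compounds shown here, no measured step touches this position, so nothing among the three measured compounds bears directly on it; the one step that exists, from compound 2 to compound 3, changes a different part of the molecule and is within the scatter.

With no guidance from the data, the expectation for compound 4 is a number close to that of compound 2, most likely within the scatter: the estimated step is a 1.3-fold lower number from compound 2 to compound 4 (0.12 log units; within the scatter). Compound 4 is therefore expected to give about 10000 nM, with a range from 3000 nM to 35000 nM.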

Compound 4, concentration for 50% growth inhibition: 6530 nM
The estimate for compound 4 lay 1.5-fold (0.19 log units) above the measured number; the range from low to high includes it.
By their numbers in this assay, from the lowest: compounds 4, 3 and 2 (each within the scatter of the next, the first and the last beyond it); then compound 1.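

Among these compounds, this is the first change at this position, the aromatic carbon of the five-membered aromatic ring with 2 nitrogen, and in this assay naphthalen-2-yl in place of 4-methoxyphenyl gives a 2.0-fold lower number from compound 2 to compound 4 (0.31 log units; beyond the scatter), a modest step but one that shows the group here can shift the number, which the halogen swap on the other side of the molecule could not show. The change removes the one hydrogen-bond acceptor of the 4-methoxyphenyl group and adds a second six-membered aromatic ring, and for this pair the growth inhibition does not suffer from the loss of that acceptor. Nothing measured here accounts for the step.

The compounds shown leave open whether the lower number follows from losing the methoxy group or from gaining the second ring, and a plain phenyl group at this position would separate the two. On these data alone, it also remains open how far this position tolerates other kinds of group, such as a pyridine ring or a phenyl ring carrying an amine or a carboxylic acid, and whether the naphthalen-2-yl step holds with chloro in place of bromo.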